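The source may hold more compounds than are shown below. What is called first, only, known or untested is meant among the compounds shown, and "the series" means these compounds.

Compound 1 `CCCCc1cnc(Cc2ccc(-c3ccccc3C(=O)O)cc2)[nH]1`: > 10000 nM
Compound 2 `COc1ccc(Cc2cnc(CCc3ccc(-c4ccccc4C(=O)O)cc3)[nH]2)cc1`: 5360 nM
Compound 3 `CCC(C)(C)Cc1c[nH]c(CCc2ccc(-c3ccccc3C(=O)O)cc2)n1`: 25 nM

In an in vitro functional assay on cells for agonist activity at Bombesin receptor subtype-3 (Homo sapiens), read by luminescence and calcium flux (on this read-out higher numbers stand for an effect only at larger amounts of compound and lower numbers for an effect already at smaller amounts), compound 2 gives 5360 nM, the highest of the two numbers measured. Compound 3 gives 25 nM, a gap far beyond the usual scatter. Compound 1 gives only a limit of the assay, > 10000 nM, and so the limit of > 10000 nM in this assay, at which 1 of the 3 values shown sits, marks where it sits. Compound 4 `CCCCc1cnc(CCc2ccc(-c3ccccc3C(=O)O)cc2)[nH]1` differs from compound 2 in one place: propyl in place of 4-methoxyphenyl on a saturated chain carbon bound to an aromatic carbon. Among the compounds with values here, no measured pair shows exactly this change, so its size is open. Still, compound 3 gives 25 nM with a saturated chain rather than a ring in that position, and compound 4 is expected to move in that direction, by a step of an 8.9-fold lower number from compound 2 to compound 4 (0.95 log units; beyond the scatter). Compound 4 is therefore estimated at 600 nM, most likely between 80 nM and 4000 nM.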

Compound 4, half-maximal effective concentration: 2710 nM
Estimate against measurement, compound 4: 4.5-fold (0.65 log units) below; the range from low to high includes it.
By their numbers in this assay, from the lowest: compound 3; then compounds 4 and 2 (each within the scatter of the next). At a limit, above all of these: compound 1.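

In this assay, propyl in place of 4-methoxyphenyl on a saturated chain carbon bound to an aromatic carbon gives a 2.0-fold lower number from compound 2 to compound 4 (0.30 log units; within the scatter), so at this position the aromatic ring can be swapped for a plain chain with no real change in the number. A plain butyl chain alone therefore does not reach the low number of compound 3, which gives 25 nM. Nothing measured here gives a reason for this. On these data alone, how an amine or a longer straight chain would behave at this position stays open.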